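The source may report more compounds than this note shows. Statements on the series, on what has been measured and on what is new or still open speak of the compounds shown alone.

In a functional assay on RS4-11 cells (Homo sapiens) for antiproliferative activity, read by MTT assay, with a stated time of 72 h (on this read-out higher numbers stand for weaker inhibition and lower numbers for stronger inhibition), the measured compounds read as follows:

Compound 1 `C=C(Br)C(=O)Nc1ccc2c(c1)/C(=C/c1cccs1)C(=O)N2` gives 12 nM
Compound 2 `C=C(Br)C(=O)Nc1ccc2c(c1)/C(=C\c1ccsc1)C(=O)N2` gives 190 nM
Compound 3 `Nc1ccc2c(c1)C(=Cc1ccsc1)C(=O)N2` gives > 10000 nM (a limit of the assay, not a number)

Of the two actual numbers, compound 2 with 190 nM is the higher, and compound 1 with 12 nM lies below it by more than the usual scatter. Compound 4 `C=C(Br)C(=O)Nc1ccc2c(c1)/C(=C\c1sccc1C)C(=O)N2` has not yet been measured. It carries 3-methylthiophen-2-yl in place of thiophen-3-yl on a double-bonded chain carbon bound to a double-bonded ring carbon. Among the compounds with values here, the counted change is 3-methylthiophen-2-yl in place of thiophen-3-yl on a double-bonded chain carbon bound to a double-bonded ring carbon and no measured pair shows this swap on its own, so the forecast rests on little. Within the data shown here, with compound 1 at 12 nM as the only lower number in view, the expectation leans modestly downward. In this assay the expected move is a moderate fall in the number, a 1.9-fold lower number from compound 2 to compound 4 (0.28 log units; within the scatter) and it may stay within the usual scatter. Compound 4 is estimated at 100 nM with 15 nM to 600 nM as the expected range.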

Compound 4, half-maximal inhibitory concentration: 4 nM
For compound 4 the middle estimate is 25-fold (1.40 log units) above the measured one, outside the stated range (below it).
By their numbers in this assay, from the lowest: compound 4; then compound 1; then compound 2. At a limit, above all of these: compound 3.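

In this assay, the thiophene on a double-bonded chain carbon bound to a double-bonded ring carbon proves to matter greatly: replacing thiophen-3-yl with 3-methylthiophen-2-yl gives a 48-fold lower number from compound 2 to compound 4 (1.68 log units; beyond the scatter). Within the data shown here, until now, no measured pair had isolated a change at this place, so its influence on the read-out could not be seen. The step is large even though the entering group differs only modestly from the one it replaces, yet nothing measured here explains why the number falls so far.

Going by these compounds, this single swap changes both the thiophene's point of attachment and the presence of a methyl group, so it remains open which of the two carries the step. Also open, on these data alone, is how an ethyl group or a chlorine atom in place of that methyl would read.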